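Bromo to Methyl on an Aromatic Carbon, a Second Time

This account rests on a few compounds, and the source may have more. Where it says the series, first, only, none or still open, it means among the compounds named here.

Measured compounds:
compound 1, `Cc1ccc(-c2cc(NC(=O)/C=C/c3ccc(Cl)cc3)n[nH]2)cc1`, 1190 nM
compound 2, `O=C(/C=C/c1ccc(Br)cc1)Nc1cc(-c2ccccc2)[nH]n1`, 1240 nM
compound 3, `O=C(/C=C/c1ccc(Cl)cc1)Nc1cc(-c2ccc(Br)cc2)[nH]n1`, 770 nM

In a functional assay on MCF7 cells (Homo sapiens) for antiproliferative activity, read by MTT assay, with a stated time of 48 h (a higher number here means a weaker inhibitor, a lower number a stronger inhibitor), compound 1 gives 1190 nM, compound 2 gives 1240 nM and compound 3 gives 770 nM. The three numbers sit close together, and none of the gaps between them is larger than the usual scatter.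

One change has already been tried once. Going from compound 3 to compound 1 the structure changes as methyl in place of bromo on an aromatic carbon, and in this assay this gave a 1.5-fold higher number from compound 3 to compound 1 (0.19 log units; within the scatter). The unmeasured compound 4, `Cc1ccc(/C=C/C(=O)Nc2cc(-c3ccccc3)[nH]n2)cc1`, arises from compound 2 by methyl in place of bromo on an aromatic carbon, the same kind of change at a place described in the same words. The difference between the cores of compound 2 and compound 3 is not broken down here.

Because the earlier step of a 1.5-fold higher number from compound 3 to compound 1 (0.19 log units; within the scatter) stayed within the scatter, the expected step for compound 4 is a 1.4-fold higher number from compound 2 to compound 4 (0.14 log units; within the scatter), also a small one. Compound 4 is therefore estimated at 1700 nM in this assay, with a likely range from 800 nM to 3600 nM.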

Compound 4, half-maximal inhibitory concentration: 1780 nM
Compound 4: the middle estimate sits 1.0-fold (0.02 log units) below what was measured; low and high end bracket the measured number.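

In this assay, methyl in place of bromo on the second core gives a 1.4-fold higher number from compound 2 to compound 4 (0.16 log units; within the scatter). Set beside the first case, the same change reads alike on the two cores: the same change on two cores in this assay, a 1.5-fold higher number (0.19 log units; within the scatter) from compound 3 to compound 1 and a 1.4-fold higher number (0.16 log units; within the scatter) from compound 2 to compound 4, 1.1-fold (0.03 log units) apart, within the scatter of two such steps. This shows that the small step seen on the first core was also small on the second, but each step lies within the scatter, so the data do not separate methyl from bromo on either core, and two small steps that agree are only a weak test of whether an effect carries from one core to another.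

The compounds shown leave open what other groups at the same place would give, such as an amine, a carboxylic acid or a methoxy group. They also leave open whether a step clearly beyond the scatter, should one of these groups produce it, would stay the same size on both cores.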